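The source may hold more compounds than are shown below. What is called first, only, known or untested is meant among the compounds shown, and "the series" means these compounds.

In a functional assay on A-431 cells (Homo sapiens) for cytotoxicity, read by MTT assay, with a stated time of 72 h, tested at 3 uM (a lower number here means less inhibition of growth, a higher number more inhibition of growth at the concentration tested), compound 2 `N/C(=N\NC(=S)N1CCOCC1)c1ccccn1` gives 43.1%, which places it second highest of the three numbers measured; compound 1 `N/C(=N\NC(=S)N1CCOCC1)c1ccc(F)cn1` gives 47% and compound 3 `Cc1ccnc(/C(N)=N/NC(=S)N2CCOCC2)c1` gives 35.5%, both within the scatter of compound 2. The two measured steps, a number 3.9 percentage points lower from compound 1 to compound 2 (within the scatter) and a number 7.6 percentage points lower from compound 2 to compound 3 (within the scatter), concern changes on the aromatic ring only. Compound 4 `N/C(=N\NC(=S)N1CCCC1)c1ccccn1` differs from compound 2 elsewhere: pyrrolidin-1-yl in place of morpholin-4-yl on a thiocarbonyl carbon. Going by the values given here, no measured step touches the thiocarbonyl substituent, so nothing directly bears on this change; the only guide is that both known changes stayed within the scatter. Compound 4 is therefore expected to give about 42% in this assay, within 26% to 58%, an estimated step of a number 1.1 percentage points lower from compound 2 to compound 4 (within the scatter) not beyond the scatter.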

Compound 4, percent growth inhibition at one concentration: 70.9%
Compound 4: middle estimate off by 28.9 percentage points, on the low side; the measured number lies above the stated range.
By their numbers in this assay, from the lowest: compounds 3, 2 and 1 (each within the scatter of the next, the first and the last beyond it); then compound 4.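

In this assay, the thiocarbonyl carbon proves to be a place where a single exchange reaches beyond the scatter, which neither step on the aromatic ring did: pyrrolidin-1-yl in place of morpholin-4-yl gives a number 27.8 percentage points higher from compound 2 to compound 4 (beyond the scatter). This one step changes both the ring size and the presence of the ring oxygen, so it does not separate the two. Nothing available explains the rise. Piperidin-1-yl, a six-membered ring without oxygen, would help separate them. As far as these compounds go, whether an open-chain dimethylamino group would keep the higher number also remains open.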